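Swapping a tert-butyl for a chlorophenyl on an ether oxygen

The source may hold more compounds than are shown below. What is called first, only, known or untested is meant among the compounds shown, and "the series" means these compounds.

Compound 1 `CCC(C)c1cc(C)c(C(=O)N=C(N)N)cc1S(C)(=O)=O` and compound 2 `Cc1cc(OC(C)(C)C)c(S(C)(=O)=O)cc1C(=O)N=C(N)N` share one core and were tested in a functional assay for inhibition of sodium/hydrogen exchanger (Oryctolagus cuniculus); on this read-out higher numbers stand for weaker inhibition and lower numbers for stronger inhibition. For the measured compounds named here, compound 1 gives 8 nM, and compound 2 gives 9.4 nM; the step of a 1.2-fold higher number from compound 1 to compound 2 (0.07 log units; within the scatter) shows that these two are indistinguishable, so compound 2 stands level with the only other measured compound. Compound 3 `Cc1cc(Oc2ccc(Cl)cc2)c(S(C)(=O)=O)cc1C(=O)N=C(N)N` carries 4-chlorophenyl in place of tert-butyl on an oxygen on an aromatic ring. Going by the values given here, only that single step, which lay within the scatter, bears on this change, and it concerns a different position, so it gives little guidance; the expected step for compound 3 is a 1.3-fold higher number from compound 2 to compound 3 (0.11 log units; within the scatter), with a wide range. Compound 3 is estimated at 12 nM, between 3 nM and 50 nM.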

Compound 3, half-maximal inhibitory concentration: 13 nM
Compound 3: middle estimate off by 1.1-fold (0.03 log units), on the low side; the range from low to high includes it.
By their numbers in this assay, from the lowest: compounds 1, 2 and 3 (each within the scatter of the next).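

Putting 4-chlorophenyl in place of tert-butyl on this oxygen adds an aromatic ring and a chlorine, yet in this assay the result is a 1.4-fold higher number from compound 2 to compound 3 (0.14 log units; within the scatter), so this larger group keeps the number level. Comparing 4-chlorophenoxy with sec-butyl on the aromatic carbon gives the same reading, with a 1.6-fold higher number from compound 1 to compound 3 (0.21 log units; within the scatter). Nothing available here explains this tolerance.

Still open, on these data alone, is whether the chlorine matters, which plain phenyl on the same oxygen would test. An amine-bearing chain there could show whether this position tolerates groups of other kinds.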